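Thiophene attachment swap on the dihydropyrimidinone series

The source may hold more compounds than are shown below. What is called first, only, known or untested is meant among the compounds shown, and "the series" means these compounds.

Compound 2 `CC1=C(C(=O)C2CC2)C(c2cccs2)NC(=O)N1` gives 1% in an assay on membranes from HEK293 cells for displacement of a labelled ligand from adenosine receptor A2b (Homo sapiens), read by scintillation counting, with a stated time of 30 min, tested at 1 uM (on this read-out higher numbers stand for more inhibition at the one concentration tested (going by the name of the read-out) and lower numbers for less inhibition), the lowest of the two numbers in hand. Compound 1 `CC1=C(C(=O)OC(C)(C)C)C(c2ccsc2)NC(=O)N1` gives 47% in this assay, but it differs from compound 2 in two places, so that gap cannot be assigned to either change alone. Compound 3 `CC1=C(C(=O)C2CC2)C(c2ccsc2)NC(=O)N1` differs from compound 2 by thiophen-3-yl in place of thiophen-2-yl on a saturated ring carbon. Within the data shown here, no measured pair isolates this change; compound 1 carries the entering group and reads higher, so an upward step is expected from compound 2 to compound 3, a number 19 percentage points higher from compound 2 to compound 3 (beyond the scatter), though its size is uncertain. Compound 3 is estimated at 20%, within 0% to 50%.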

Compound 3, a percentage reported as inhibition, at one concentration (the size of the read-out at that concentration, not a potency): 1%
Estimate against measurement, compound 3: 19 percentage points above; measured number inside the range.
By their numbers in this assay, from the lowest: compounds 2 and 3 (each within the scatter of the next); then compound 1.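

With the cyclopropylcarbonyl group in place, the swap to thiophen-3-yl on the saturated ring carbon gives in this assay no change at the digits printed from compound 2 to compound 3 (within the scatter). The large gap to compound 1 can now be assigned to one place: cyclopropyl in place of tert-butoxy on the carbonyl carbon gives a number 46 percentage points lower from compound 1 to compound 3 (beyond the scatter). Nothing at hand explains either result.

The compounds shown leave open whether thiophen-2-yl and thiophen-3-yl also read alike with tert-butoxy on the carbonyl carbon. Also open, going by these compounds, is whether methoxy or dimethylamino there would read nearer compound 1 or compound 3.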